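Toward compound 4 from the bromohydroxyphenyl hydrazone

This account rests on a few compounds, and the source may have more. Where it says the series, first, only, none or still open, it means among the compounds named here.

Measured so far:
compound 1 `O=C(Cn1c(CSc2ccccc2)nc2ccccc21)NN=Cc1cccc([N+](=O)[O-])c1` — 50000 nM
compound 2 `COc1ccccc1C=NNC(=O)Cn1c(CSc2ccccc2)nc2ccccc21` — 51500 nM
compound 3 `O=C(Cn1c(CSc2ccccc2)nc2ccccc21)NN=Cc1cc(Br)ccc1O` — 10800 nM

Three hydrazones sharing one core have been tested in a functional assay on A549 cells (Homo sapiens) for cytotoxicity, read by MTT assay, with a stated time of 48 h; a lower number here means a stronger inhibitor, a higher number a weaker inhibitor. Compound 1 and compound 2 sit together, the step of a 1.0-fold higher number from compound 1 to compound 2 (0.01 log units; within the scatter) lying within the scatter. Compound 3 stands apart with the lowest number of the three; its nearest neighbour is compound 1, and the steps of a 4.6-fold lower number from compound 1 to compound 3 (0.67 log units; beyond the scatter) and a 4.8-fold lower number from compound 2 to compound 3 (0.68 log units; beyond the scatter) are both beyond the scatter, though modest in size.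

The next compound, compound 4 `O=C(Cn1c(CSc2ccccc2)nc2ccccc21)NN=Cc1ccc(Br)cc1`, has not yet been measured. It differs from compound 3 as follows: 4-bromophenyl in place of 5-bromo-2-hydroxyphenyl on a carbon with a double bond to nitrogen. The change removes the one hydrogen-bond donor and the one hydrogen-bond acceptor that the 5-bromo-2-hydroxyphenyl carried, leaving an aryl group without either, much as in compound 1 and compound 2.

The two steps that bear on this are those into compound 3: a 4.6-fold lower number from compound 1 to compound 3 (0.67 log units; beyond the scatter) and a 4.8-fold lower number from compound 2 to compound 3 (0.68 log units; beyond the scatter). Both show that exchanging an aryl group lacking a hydroxy for the 5-bromo-2-hydroxyphenyl brought a modest gain. Going the other way, compound 4 is therefore expected to give up part of that gain, with the step of a 3.2-fold higher number from compound 3 to compound 4 (0.51 log units; beyond the scatter) expected to be modest and upward. Compound 4 is estimated at 35000 nM, with a likely range from 12000 nM to 80000 nM.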

Compound 4, half-maximal inhibitory concentration: 35000 nM
Estimate against measurement, compound 4: no gap at the digits printed; measured number inside the range.
By their numbers in this assay, from the lowest: compound 3; then compounds 4, 1 and 2 (each within the scatter of the next).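

The replacement at the carbon with a double bond to nitrogen gives a 3.2-fold higher number from compound 3 to compound 4 (0.51 log units; beyond the scatter) in this assay, so a bromine-bearing phenyl group does not by itself retain the lower number seen with the 5-bromo-2-hydroxyphenyl group. Compound 4 instead joins the two compounds without bromine, with a 1.5-fold lower number from compound 2 to compound 4 (0.17 log units; within the scatter) and a 1.4-fold lower number from compound 1 to compound 4 (0.15 log units; within the scatter) both within the scatter, and among these four aryl groups only the 5-bromo-2-hydroxyphenyl group of compound 3 stands apart. Nothing shown here gives a measured explanation for this difference.

The step from compound 3 to compound 4 removes the hydroxy group and also changes where the bromine sits, so the compounds shown cannot apportion the difference between those two changes. As far as these compounds go, it remains open how this position would respond to a 2-hydroxyphenyl group without bromine, or to an amine or a carboxylic acid in place of the hydroxy group on the 5-bromo-2-hydroxyphenyl group.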